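Trading a Chloro Group for an Imidazole Ring

The source may report more compounds than this note shows. Statements on the series, on what has been measured and on what is new or still open speak of the compounds shown alone.

Measured so far:
Compound 1, `COc1cc(OC)c(OC)cc1/C=C/C(=O)c1ccc(Cl)cc1`: in a functional assay on MCF7 cells (Homo sapiens) for inhibition, read by MTT assay, with a stated time of 72 h (a lower number here means a stronger inhibitor, a higher number a weaker inhibitor), compound 1 gives 29500 nM.
Compound 2, `COc1cc(OC)c(OC)cc1/C=C/C(=O)c1cc(Cc2ccccc2)cc(Cc2ccccc2)c1`: in this assay compound 2 gives 23300 nM.

Both numbers are high, so neither compound is a strong inhibitor. Compound 1 has the higher of the two numbers, but its gap to compound 2 lies within the usual scatter, so the two cannot be told apart on these data. Compound 3, `COc1cc(OC)c(OC)cc1/C=C/C(=O)c1ccc(-c2c[nH]cn2)cc1`, has not yet been measured. It differs from compound 1 in one place: 1H-imidazol-4-yl in place of chloro on an aromatic carbon. Among the compounds with values here, no step between measured compounds is available to guide this change, so the expectation in this assay is a small step at most, within or only just beyond the scatter, with no firm direction. Compound 3 is therefore estimated at 20000 nM, within a range of 5000 nM to 60000 nM. This estimate means an expected 1.5-fold lower number from compound 1 to compound 3 (0.17 log units; within the scatter).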

Compound 3, half-maximal inhibitory concentration: > 150000 nM
Compound 3 ended at the assay's limit; the forecaster's own chance of this, stated with the estimate: 10%; at least 7.5-fold (0.87 log units) between middle value and limit.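

The earlier compounds shown here offered no step to read, and this one shows that the position, on an aromatic carbon para to a large group, does not tolerate every change: 1H-imidazol-4-yl in place of chloro gives an at least 5.0-fold higher number from compound 1 to compound 3 (0.70 log units; beyond the scatter) in this assay. Compound 3 gives > 150000 nM, which is a limit of the assay and not a number. The full size of the step therefore cannot be read, because the reading stops at that limit: the limit of > 150000 nM in this assay, at which 1 of the 3 values shown sits.

The compounds shown cannot tell whether the weaker result belongs to the imidazole ring in particular or would follow from other replacements of chloro here. From the compounds shown here alone, it also remains open whether an amine or a pyridine ring in the same place would stay close to compound 1 or also reach the limit.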